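This account rests on a few compounds, and the source may have more. Where it says the series, first, only, none or still open, it means among the compounds named here.

Measured so far in a functional assay on L1210 cells (Mus musculus) for inhibition, read by cell counting, with a stated time of 2 days; on this read-out higher numbers stand for weaker inhibition and lower numbers for stronger inhibition:

Compound 1 `CCc1ccc(-c2nn3cc(-c4cccc(N)c4)nc3s2)cc1` gives 6000 nM.
Compound 2 `Nc1cccc(-c2cn3nc(-c4cccs4)sc3n2)c1` gives > 250000 nM, a limit of this assay and not a number.
Compound 3 `COc1ccc(-c2nn3cc(-c4cccc(N)c4)nc3s2)cc1` gives >= 250000 nM, also a limit and not a number.

Compound 3 therefore stands only at a limit: the limit of >= 250000 nM in this assay, at which 1 of the 3 values shown sits. One further value shown is likewise a limit, (the limit of > 250000 nM in this assay, at which 1 of the 3 values shown sits).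

Compound 4 `Cc1ccc(-c2nn3cc(-c4cccc(N)c4)nc3s2)cc1` differs from compound 3 by methyl in place of methoxy on an aromatic carbon. For the measured compounds named here, the one measured step that bears on this change is an at least 41-fold higher number from compound 1 to compound 3 (1.61 log units; beyond the scatter), where ethyl in place of methoxy gave the far lower number. Methyl sits between those two groups, so the number is expected to fall from compound 3, though the size is uncertain. The expected step is an at least 8.3-fold lower number from compound 3 to compound 4 (0.92 log units; beyond the scatter). Compound 4 is estimated at 30000 nM, within 6000 nM to 250000 nM.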

Compound 4, half-maximal inhibitory concentration: 4800 nM
Compound 4: the middle estimate sits 6.3-fold (0.80 log units) above what was measured; measured number outside the range, below it.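

Methyl and ethyl on this aromatic carbon, para to a large group, cannot be told apart (a 1.3-fold lower number from compound 1 to compound 4 (0.10 log units; within the scatter)). Methoxy stands apart from both (an at least 52-fold lower number from compound 3 to compound 4 (1.71 log units; beyond the scatter)), a step that starts from a limit and not from a number. The 4-methylphenyl group in place of thiophen-2-yl also brings a large change (an at least 52-fold lower number from compound 2 to compound 4 (1.71 log units; beyond the scatter)), again starting from a limit and not from a number. From the compounds shown here alone, whether a longer chain such as propyl keeps this level stays open. So does whether a chlorine or an amine at this place reads like methyl or like methoxy.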